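From compound 3 to compound 4: one chloro added

The source may report more compounds than this note shows. Statements on the series, on what has been measured and on what is new or still open speak of the compounds shown alone.

Three compounds have been measured in a functional assay on cells (Melanoma cell, Homo sapiens) for cytotoxicity, read by sulforhodamine B assay, with a stated time of 48 h; a higher number here means a weaker inhibitor of growth, a lower number a stronger inhibitor of growth:
compound 1 `COc1ccc(OC)c(-c2cc(-c3ccccc3)nn2-c2ccc(S(=O)(=O)NC(C)=O)cc2)c1` gives 36200 nM;
compound 2 `COc1ccc(OC)c(-c2cc(-c3ccc(Cl)cc3)nn2-c2ccc(S(=O)(=O)NC(C)=O)cc2)c1` gives 28700 nM;
compound 3 `Oc1ccc(O)c(-c2cc(-c3ccccc3)nn2-c2ccccc2)c1` gives 63900 nM.

Compound 3 carries the highest of the three numbers. Its gap to compound 1 lies within the usual scatter of this assay, so the two cannot be ranked; its gap to compound 2 lies beyond the scatter, so compound 2 does inhibit growth more strongly than compound 3.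

Compound 4 `Oc1ccc(O)c(-c2cc(-c3ccc(Cl)cc3)nn2-c2ccccc2)c1` is built from compound 3 by a single change: chloro in place of hydrogen on an aromatic carbon. Among the compounds with values here, the only measured step that matches this change is a 1.3-fold lower number from compound 1 to compound 2 (0.10 log units; within the scatter), a step too small to count, made on a pair that shares the same core but carries a different set of outer groups. On that evidence, the same change on compound 3 is expected to give no step beyond the scatter. Compound 4 is therefore estimated at 55000 nM, with a range from 30000 nM to 100000 nM. The expected step is a 1.2-fold lower number from compound 3 to compound 4 (0.07 log units; within the scatter).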

Compound 4, concentration for total growth inhibition: 32500 nM
Beside the measured number, compound 4's estimate is 1.7-fold (0.23 log units) above it; low and high end bracket the measured number.
By their numbers in this assay, from the lowest: compounds 2, 4, 1 and 3 (each within the scatter of the next, the first and the last beyond it).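

Phenyl to 4-chlorophenyl can now be read on a second core in this assay, and this step, a 2.0-fold lower number from compound 3 to compound 4 (0.29 log units; within the scatter), means that chloro at this position has no effect on growth inhibition that can be told apart from the scatter on this core either. The two readings also agree with each other: the same change on two cores in this assay, a 1.3-fold lower number (0.10 log units; within the scatter) from compound 1 to compound 2 and a 2.0-fold lower number (0.29 log units; within the scatter) from compound 3 to compound 4, 1.6-fold (0.19 log units) apart, within the scatter of two such steps. The earlier result rested on one pair, whereas two pairs with different outer groups now give the same reading, though two pairs are still too few to make a rule.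

Only hydrogen and chloro appear at this position in the compounds shown, so what an amine or a carboxylic acid there would do remains open. As far as these compounds go, whether any group at this position can give a step beyond the scatter also remains open.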